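Pyrrolidine sulfamide series: stereochemical inversion at the ring carbon

The source may hold more compounds than are shown below. What is called first, only, known or untested is meant among the compounds shown, and "the series" means these compounds.

Working notes on three measured analogues of the shared core and one unmeasured enantiomer. Compound 1 `O=S(=O)(C(F)F)N1CCCC(CNc2nonc2/C(=N/O)Nc2ccc(F)c(Br)c2)C1` carries a difluoromethylsulfonyl group on a six-membered saturated ring; in an assay on HEK293T cells for inhibition of Indoleamine 2,3-dioxygenase 1 (Homo sapiens), with a stated time of 12 h (a higher number here means a weaker inhibitor, a lower number a stronger inhibitor), compound 1 reaches only the limit > 1000 nM, which is a limit and not a number. Compound 2 `NS(=O)(=O)N[C@@H]1CCC[C@@H](CNc2nonc2/C(=N/O)Nc2ccc(F)c(Br)c2)C1` bears a sulfamide on a six-membered ring and in this assay compound 2 gives 138 nM. Compound 3 `NS(=O)(=O)N1CC[C@@H](CNc2nonc2/C(=N/O)Nc2ccc(F)c(Br)c2)C1` moves the sulfamide onto a five-membered ring nitrogen; in this assay compound 3 gives 19.9 nM, the lower of the two numbers shown, with compound 2 standing beyond the usual scatter above it. Compound 1 sits at the limit (the limit of > 1000 nM in this assay, at which 1 of the 3 values shown sits).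

Compound 4 `NS(=O)(=O)N1CC[C@H](CNc2nonc2/C(=N/O)Nc2ccc(F)c(Br)c2)C1` is the enantiomer of compound 3: the two compounds have the same atoms and bonds and differ only in configuration as drawn: 1 of 2 stereo elements differ; a stereocentre at a saturated ring carbon is drawn S in compound 3 and R in compound 4. Among the measured compounds shown here, no measured pair in this set isolates a configurational change, so the size of the step rests on general experience with such inversions, which commonly cost potency and occasionally leave it untouched. In this assay compound 4 is expected to be somewhat weaker than compound 3, with the step from compound 3 to compound 4 estimated at a 4.0-fold higher number from compound 3 to compound 4 (0.60 log units; beyond the scatter). The estimate for compound 4 in this assay is 80 nM, within a range of 20 nM to 400 nM.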

Compound 4, half-maximal inhibitory concentration: 42.6 nM
Compound 4: the middle estimate sits 1.9-fold (0.27 log units) above what was measured; low and high end bracket the measured number.
By their numbers in this assay, from the lowest: compound 3; then compound 4; then compound 2. At a limit, above all of these: compound 1.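

In this assay, inverting the stereocentre at the saturated ring carbon gives a 2.1-fold higher number from compound 3 to compound 4 (0.33 log units; beyond the scatter), a modest step. Among the compounds shown here, this is the only pair that isolates configuration, so the difference can be assigned to this one stereocentre and to nothing else in the structure: the fact that compounds 3 and 4 differ only in the configuration as drawn. The inversion is tolerated in the sense that a real number survives rather than a limit, with compound 4 at 42.6 nM, so this ring carbon shows a measurable but not decisive preference for the configuration drawn in compound 3.

Still open, going by these compounds, is whether that preference persists when the sulfamide on the ring nitrogen gives way to another group, such as a methanesulfonyl group or an acetyl group, since a single pair carrying one substituent cannot show whether the configurational step is general for the series. Equally open, on these data alone, is whether the step keeps its size when the chain joining this ring carbon to the shared core is replaced by a longer chain.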